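The source may hold more compounds than are shown below. What is called first, only, known or untested is meant among the compounds shown, and "the series" means these compounds.

Two compounds share one core and differ only in the group on the ring at the far end of the chain. Compound 1 `COc1ccc(-c2cc3ccccc3nc2/C=C/C(=O)c2ccc(F)cc2)cc1` gives 830 nM in a functional assay on MDA-MB-231 cells (Homo sapiens) for antiproliferative activity, read by XTT assay, with a stated time of 72 h; a lower number here means a stronger inhibitor, a higher number a weaker inhibitor. Compound 2 `COc1ccc(C(=O)/C=C/c2nc3ccccc3cc2-c2ccc(OC)cc2)cc1` gives 7540 nM in this assay, the step from it being a 9.1-fold higher number from compound 1 to compound 2 (0.96 log units; beyond the scatter). Among the two numbers, compound 2 holds the highest, with compound 1 as its only neighbour.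

Compound 3 `COc1ccc(-c2cc3ccccc3nc2/C=C/C(=O)c2ccc(OC)cc2OC)cc1` is made from compound 2 by methoxy in place of hydrogen on an aromatic carbon. Within the data shown here, the single measured step swaps one group for another on that ring; no measured step adds a group beside one already present, so it gives only a rough guide and its size does not transfer directly. Without a closer comparison, a change of compound 3 against compound 2 in this assay that stays within the scatter is expected, as a 1.0-fold lower number from compound 2 to compound 3 (0.00 log units; within the scatter). Compound 3 is estimated at 7500 nM, within 2500 nM to 22000 nM.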

Compound 3, half-maximal inhibitory concentration: 3210 nM
Compound 3: the middle estimate sits 2.3-fold (0.37 log units) above what was measured; low and high end bracket the measured number.
By their numbers in this assay, from the lowest: compound 1; then compound 3; then compound 2.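

Adding a methoxy group to the 4-methoxyphenyl ring to give 2,4-dimethoxyphenyl, ortho to a large group, produces a 2.3-fold lower number from compound 2 to compound 3 (0.37 log units; beyond the scatter) in this assay, so this carbon is a second place on the ring where a change moves the number, and here the added group gives a stronger inhibitor rather than a weaker one. The recovery is only partial, since replacing the 4-fluorophenyl of the better compound with 2,4-dimethoxyphenyl still gives a 3.9-fold higher number from compound 1 to compound 3 (0.59 log units; beyond the scatter) and the fluoro compound keeps the lowest number of the series. Nothing available here accounts for either step.

As far as these compounds go, it remains open whether an amine or a hydroxyl on that same carbon would shift the number in the same direction as methoxy. From the compounds shown here alone, it is also open whether a methoxy group there would help when the fluoro group is kept on the ring.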